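The source may report more compounds than this note shows. Statements on the series, on what has been measured and on what is new or still open speak of the compounds shown alone.

Measured in a functional assay on DU-145 cells (Homo sapiens) for antiproliferative activity, read by MTT assay, with a stated time of 24 h; a higher number here means a weaker inhibitor, a lower number a stronger inhibitor:
compound 1 `COc1cc(C(=O)/C=C/c2cc(-c3cc(OC)c(OC)c(OC)c3)n3nc(-c4ccccc4)cc3n2)cc(OC)c1OC`: 34900 nM
compound 2 `COc1cc(-c2cc(C(=O)/C=C/c3ccc(Cl)cc3)nc3cc(-c4ccccc4)nn23)cc(OC)c1OC`: 19500 nM
compound 3 `COc1cc(-c2cc(/C=C/C(=O)c3ccc(C)cc3)nc3cc(-c4ccccc4)nn23)cc(OC)c1OC`: 27100 nM

Compound 3 has the second highest of the three numbers, and both of its neighbours sit close: the steps of a 1.3-fold lower number from compound 1 to compound 3 (0.11 log units; within the scatter) and a 1.4-fold higher number from compound 2 to compound 3 (0.14 log units; within the scatter) lie within the scatter, so no order among the three can be read. Compound 4 `COc1cc(-c2cc(/C=C/C(=O)c3ccc(C)c(C)c3)nc3cc(-c4ccccc4)nn23)cc(OC)c1OC` differs from compound 3 by methyl in place of hydrogen on an aromatic carbon. Among the measured compounds shown here, no measured step tests a methyl on that ring; the two steps that do change the aryl on the carbonyl side stay within the scatter, so in this assay no step beyond the scatter is expected. Compound 4 is therefore estimated at 25000 nM, between 10000 nM and 60000 nM. The expected step is a 1.1-fold lower number from compound 3 to compound 4 (0.04 log units; within the scatter).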

Compound 4, half-maximal inhibitory concentration: 15400 nM
Beside the measured number, compound 4's estimate is 1.6-fold (0.21 log units) above it; the range from low to high includes it.
By their numbers in this assay, from the lowest: compounds 4, 2, 3 and 1 (each within the scatter of the next, the first and the last beyond it).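

The first test of a methyl added to the 4-methylphenyl, giving 3,4-dimethylphenyl, is the step of a 1.8-fold lower number from compound 3 to compound 4 (0.25 log units; within the scatter) in this assay and shows no effect separable from the scatter. Among the compounds shown here, the step of a 1.3-fold lower number from compound 2 to compound 4 (0.10 log units; within the scatter) also stays within it, whereas a 2.3-fold lower number from compound 1 to compound 4 (0.36 log units; beyond the scatter) is the first step beyond the scatter, though modest. No measured evidence bearing on these numbers is available.

Going by these compounds, whether an amine, a carboxylic acid or a longer chain on this ring would give a step beyond the scatter from compound 3 remains open.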